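Dropping the Methoxy Group of Compound 2

The source may hold more compounds than are shown below. What is called first, only, known or untested is meant among the compounds shown, and "the series" means these compounds.

Compound 1 `Cc1nn(C(C)(C)C)c2nc(C(C)C)c(/C=C/[C@@H](O)C[C@@H](O)CC(=O)O)c(-c3ccc(F)cc3)c12`: 86%
Compound 2 `COc1ccc(-n2nc(C)c3c(-c4ccc(F)cc4)c(/C=C/[C@@H](O)C[C@@H](O)CC(=O)O)c(C(C)C)nc32)cc1`: 48.7%

In an in vivo functional assay on the whole organism for inhibition of 3-hydroxy-3-methylglutaryl-coenzyme A reductase (Rattus norvegicus), at a dose of 2 mg/kg by the oral route (on this read-out higher numbers stand for a stronger effect at the one dose given and lower numbers for a weaker effect), compound 1 gives 86%, while compound 2 gives 48.7%. Among the compounds with values here, compound 2 therefore stands at the lower of the two numbers, and the only measured step, a number 37.3 percentage points lower from compound 1 to compound 2 (beyond the scatter), is large and beyond the scatter. Compound 3 `Cc1nn(-c2ccccc2)c2nc(C(C)C)c(/C=C/[C@@H](O)C[C@@H](O)CC(=O)O)c(-c3ccc(F)cc3)c12` differs from compound 2 by hydrogen in place of methoxy on an aromatic carbon. Within the data shown here, no measured step touches this change: the one step known concerns the exchange of tert-butyl for 4-methoxyphenyl on the aromatic nitrogen, not the methoxy itself, so it says nothing about what losing the methoxy does. Compound 3 keeps the aryl group on the nitrogen that goes with the lower number of compound 2, so the expected step of a number 3.3 percentage points higher from compound 2 to compound 3 (within the scatter) is taken as none beyond the scatter. On that basis compound 3 is estimated at 52%, with a range from 28% to 76% in this assay.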

Compound 3, a percentage reported as inhibition, in the whole organism at one dose (the size of the read-out at that dose, not a potency): 19.9%
Estimate against measurement, compound 3: 32.1 percentage points above, outside the stated range (below it).
By their numbers in this assay, from the lowest: compound 3; then compound 2; then compound 1.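

The methoxy group proves to matter in its own right: in this assay, hydrogen in its place gives a number 28.8 percentage points lower from compound 2 to compound 3 (beyond the scatter), so the group carried at this place on the ring affects the effect at the one dose given. The cost of leaving tert-butyl on the aromatic nitrogen also depends on what the aryl group carries, with phenyl giving a number 66.1 percentage points lower from compound 1 to compound 3 (beyond the scatter) against a number 37.3 percentage points lower from compound 1 to compound 2 (beyond the scatter) for 4-methoxyphenyl. No available measurement bears on why removing the methoxy group lowers the number.

On these data alone, it remains open whether a hydroxyl or a dimethylamino group at the same place on the ring would give a number nearer that of compound 2 or that of compound 3. As far as these compounds go, it is equally open how an isopropyl or a cyclohexyl group on the aromatic nitrogen would compare with tert-butyl.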